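This account rests on a few compounds, and the source may have more. Where it says the series, first, only, none or still open, it means among the compounds named here.

Results so far in a functional assay on DU-145 cells (Homo sapiens) for inhibition, read by trypan blue exclusion, with a stated time of 72 h; on this read-out higher numbers stand for weaker inhibition and lower numbers for stronger inhibition:
- compound 1 `Cn1c(=O)c(S(=O)(=O)c2ccc(F)cc2F)cc2cnc(Nc3ccc4[nH]c(C(=O)O)cc4c3)nc21` (value 10000 nM)
- compound 2 `COC(=O)Cn1c(=O)c(S(=O)(=O)c2ccc(F)cc2F)cc2cnc(Nc3ccc4[nH]ccc4c3)nc21` (value 10000 nM)
- compound 3 `Cn1c(=O)c(S(=O)(=O)c2ccccc2)cc2cnc(Nc3cnc4[nH]ccc4c3)nc21` (value 1000 nM)

Compound 1 stands level with compound 2, and their shared number is the highest of the three. Compound 3 has a clearly lower number, well beyond the usual scatter.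

The next molecule is compound 4 `Cn1c(=O)c(S(=O)(=O)c2ccc(F)cc2F)cc2cnc(Nc3ccc4sccc4c3)nc21`, which differs from compound 1 as follows: 1-benzothiophen-5-yl in place of 2-carboxy-1H-indol-5-yl on a nitrogen on an aromatic ring. In short, 1-benzothiophen-5-yl replaces 2-carboxy-1H-indol-5-yl on a nitrogen on an aromatic ring.

Going by the values given here, no two measured compounds differ in one place only, so this swap has no direct precedent. The indirect hints conflict. Compound 3, which has no carboxy group, gives 1000 nM here, but compound 2, also without one, gives 10000 nM in the same test.

A moderate fall in the number is therefore expected, with the estimated step being a 3.3-fold lower number from compound 1 to compound 4 (0.52 log units; beyond the scatter) in this assay, though this is uncertain. For compound 4 the estimated value is 3000 nM, with an expected range of 500 nM to 15000 nM as the likely span.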

Compound 4, half-maximal inhibitory concentration: 500 nM
Estimate against measurement, compound 4: 6.0-fold (0.78 log units) above, within the range that was stated.
By their numbers in this assay, from the lowest: compounds 4 and 3 (each within the scatter of the next); then compounds 1 and 2 (each within the scatter of the next).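

In this assay, going by these compounds alone, the group on a nitrogen on an aromatic ring can now be read as a single change for the first time: 1-benzothiophen-5-yl in place of 2-carboxy-1H-indol-5-yl gives a 20-fold lower number from compound 1 to compound 4 (1.30 log units; beyond the scatter). Within the data shown here, with the rest of compound 1 kept, this position alone can therefore move the number by a large step, something the earlier compounds could not show, as no two of them differ in one place only. The swap removes the carboxy group and brings in sulfur together, and nothing measured here says why the number moves.

On these data alone, it remains open whether the step follows the loss of the carboxy group or the arrival of the sulfur. Also open, as far as these compounds go, is how an aminomethyl group on the 1H-indol-5-yl would compare with the carboxy group of compound 1.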